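Removing a Methoxy Group: Expected Toxicity of Compound 3

The compounds below may be only part of what the source reports. "The series", "measured", "known", "first", "only" and "open" are said of these compounds alone.

Compound 2 `COc1ccccc1-c1nnc(-c2sc(-c3cccnc3)nc2C)o1` was tested in an ADME assay on HeLa cells (Homo sapiens) for cytotoxicity, read by MTT assay; on this read-out lower numbers stand for higher toxicity in this test and higher numbers for lower toxicity in this test. In this assay compound 2 gives only a limit, > 100 ug/mL, not a number. Compound 1 `Cc1nc(-c2cccnc2)sc1-c1nnc(-c2ccc([N+](=O)[O-])cc2)o1` likewise gives a limit in this assay, > 100 ug/mL. Both values sit at the same point, (the limit of > 100 ug/mL in this assay, at which 2 of the 2 values shown sit), so compound 2 stands together with compound 1. Compound 3 `Cc1nc(-c2cccnc2)sc1-c1nnc(-c2ccccc2)o1` is not yet measured; it differs from compound 2 by hydrogen in place of methoxy on an aromatic carbon. Within the data shown here, with no measured step to lean on, the change is expected to move compound 3 little in this assay, so a step that the limit leaves unreadable from compound 2 to compound 3 is expected to be none beyond the scatter. Compound 3 is estimated at 150 ug/mL, between 60 ug/mL and 400 ug/mL.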

Compound 3, half-maximal cytotoxic concentration: > 100 ug/mL
Compound 3: no number, only a limit; the forecaster's own chance of this, stated with the estimate: 80%; the middle value lies beyond the limit too.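

Compound 1, compound 2 and compound 3 all give only a limit in this assay, so no step between them can be read: the limit of > 100 ug/mL in this assay, at which 3 of the 3 values shown sit.

The compounds shown leave open how far each lies past that limit, and whether exchanging methoxy, nitro and hydrogen changes the read-out at all.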